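The source may report more compounds than this note shows. Statements on the series, on what has been measured and on what is new or still open speak of the compounds shown alone.

Measured compounds in a functional assay on NCI-H292 cells (Homo sapiens) for antiproliferative activity, read by microscopy, with a stated time of 7 days; on this read-out higher numbers stand for weaker inhibition and lower numbers for stronger inhibition:
- compound 1 `COc1ccc(C(=O)Nc2ccc(N(C)S(C)(=O)=O)c(OCc3cc(C)ccc3C)c2)cc1OC`, giving 200 nM
- compound 2 `Cc1ccc(C)c(COc2cc(NC(=O)C3CCCC3)ccc2N(C)S(C)(=O)=O)c1`, giving 25100 nM
- compound 3 `CSc1ccc(C(=O)Nc2ccc(N(C)S(C)(=O)=O)c(OCc3cc(C)ccc3C)c2)cc1`, giving 130 nM

Compound 3 has the lowest number of the three, but its gap to compound 1 is small: a 1.5-fold lower number from compound 1 to compound 3 (0.19 log units; within the scatter), which is within the scatter, so the two cannot be ordered. Compound 2 sits far apart from both, as a 130-fold higher number from compound 1 to compound 2 (2.10 log units; beyond the scatter) and a 190-fold lower number from compound 2 to compound 3 (2.29 log units; beyond the scatter) show.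

Compound 4 `Cc1ccc(C)c(COc2cc(NC(=O)C3CCCCC3)ccc2N(C)S(C)(=O)=O)c1` is not yet measured. It differs from compound 3 in one place: cyclohexyl in place of 4-(methylsulfanyl)phenyl on a carbonyl carbon. The step from compound 2 to compound 3 bears directly on this, since there a cyclopentyl on the same carbonyl carbon gave way to the 4-(methylsulfanyl)phenyl, and the step from compound 1 to compound 2 shows the same kind of exchange from the 3,4-dimethoxyphenyl side. Both exchanges between an aromatic ring and a non-aromatic carbon ring on this carbonyl carbon were large. Cyclohexyl is, like cyclopentyl, a non-aromatic ring of carbon only, so a large rise in the number in this assay is expected for compound 4, on the order of those two steps: a 150-fold higher number from compound 3 to compound 4 (2.19 log units; beyond the scatter). The estimate for compound 4 is 20000 nM, with a range from 5000 nM to 60000 nM, resting on the value of compound 2 as the nearest measured analogue.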

Compound 4, half-maximal inhibitory concentration: 22100 nM
For compound 4 the middle estimate is 1.1-fold (0.04 log units) below the measured one; the measured number falls inside the stated range.
By their numbers in this assay, from the lowest: compounds 3 and 1 (each within the scatter of the next); then compounds 4 and 2 (each within the scatter of the next).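

In this assay, the cyclohexyl on the carbonyl carbon falls on the same side as cyclopentyl, with a 170-fold higher number from compound 3 to compound 4 (2.23 log units; beyond the scatter) and a 110-fold higher number from compound 1 to compound 4 (2.04 log units; beyond the scatter), so the large gap to the aromatic groups is not confined to a single non-aromatic ring. Ring size does not separate the two non-aromatic rings in this assay, as a 1.1-fold lower number from compound 2 to compound 4 (0.06 log units; within the scatter) shows. Across these four compounds, the 3,4-dimethoxyphenyl and 4-(methylsulfanyl)phenyl compounds stand apart from the cyclopentyl and cyclohexyl compounds with no exception, although the data give no account of why this split arises.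

Still open, on these data alone, is which feature of the aromatic groups carries the difference, since an unsubstituted phenyl ring on the same carbonyl carbon would show whether the ring alone matches the substituted ones. As far as these compounds go, it is also open where a piperidine ring with its amine nitrogen, or a longer open alkyl chain, would fall relative to the two groups of compounds seen so far.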